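Hydroxy for amino on the sugar of the azide core

The compounds below may be only part of what the source reports. "The series", "measured", "known", "first", "only" and "open" are said of these compounds alone.

Measured so far:
Compound 1 `COC(=O)[C@H]1C[C@H](OCCN=[N+]=[N-])[C@@H](O[C@H]2O[C@H](CN)[C@@H](O)[C@H](O)[C@@H]2O)C[C@@H]1C(=O)OC` gives 481000 nM in an assay on isolated protein for binding affinity to CD209 antigen (Homo sapiens), read by surface plasmon resonance; a higher number here means a weaker inhibitor, a lower number a stronger inhibitor.
Compound 2 `[N-]=[N+]=NCCO[C@H]1C[C@H](C(=O)OCc2ccc(CN)cc2)[C@@H](C(=O)OCc2ccc(CN)cc2)C[C@@H]1O[C@H]1O[C@H](CN)[C@@H](O)[C@H](O)[C@@H]1O` gives 254000 nM in this assay.

Compound 1 holds the higher of the two numbers, but its gap to compound 2 lies within the scatter, so the two are not separated by this assay and no order can be read between them. Going by the values given here, no step between two measured compounds that differ in one place is available.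

Compound 3 `COC(=O)[C@H]1C[C@H](OCCN=[N+]=[N-])[C@@H](O[C@H]2O[C@H](CO)[C@@H](O)[C@H](O)[C@@H]2O)C[C@@H]1C(=O)OC` differs from compound 1 in one place: hydroxy in place of amino on a saturated chain carbon bound to a saturated ring carbon. Both groups that leave and enter carry one donor and one acceptor and no charge, so the count of polar features on that chain carbon is unchanged.

Among the compounds with values here, with no measured step of this kind to lean on, a modest move is expected, if any, and the direction is uncertain; a small shift toward a higher number seems somewhat more likely than a lower one, but a result inside the scatter would not surprise. Compound 3 is expected to give 700000 nM, in a range of 300000 nM to 1600000 nM. The step from compound 1 to compound 3 is thus estimated at a 1.5-fold higher number from compound 1 to compound 3 (0.16 log units; within the scatter).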

Compound 3, half-maximal inhibitory concentration: 956000 nM
For compound 3 the middle estimate is 1.4-fold (0.14 log units) below the measured one; the range from low to high includes it.
By their numbers in this assay, from the lowest: compounds 2, 1 and 3 (each within the scatter of the next, the first and the last beyond it).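

Going by these compounds alone, this is the first pair that differs in one place, and in this assay it gives a 2.0-fold higher number from compound 1 to compound 3 (0.30 log units; within the scatter). Hydroxy in place of amino on a saturated chain carbon bound to a saturated ring carbon therefore does not separate the two compounds in this read-out, so the aminomethyl to hydroxymethyl change on the shared core has no effect that can be told from repeat scatter, and neither group can be ranked above the other at this position. No measurement at hand bears on why this step is as it is.

As far as these compounds go, it remains open whether a group of another kind on that chain carbon, such as a carboxylic acid, a guanidine or a longer chain ending in an amine, would give a step beyond the scatter. Also open, from the compounds shown here alone, is whether the same hydroxy for amino change would give a similar step on the core of compound 2, which carries the two esters of 4-(aminomethyl)benzyl alcohol, since a single pair cannot show whether the step holds on another background.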